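The compounds below may be only part of what the source reports. "The series", "measured", "known", "first", "only" and "open" are said of these compounds alone.

In a functional assay on HepG2 cells (Homo sapiens) for cytotoxicity, read by MTT assay, with a stated time of 72 h (a higher number here means a weaker inhibitor, a lower number a stronger inhibitor), compound 1 (`CCN(CC)c1ccc(/C=N/NC(=O)Nc2cc3c(Nc4ccc(F)c(Cl)c4)ncnc3cc2O[C@H]2CCOC2)c(O)c1`) gives 15700 nM, compound 2 (`COc1cc2ncnc(Nc3ccc(F)c(Cl)c3)c2cc1NC(=O)N/N=C/c1ccc(O)c(Br)c1`) gives 23800 nM and compound 3 (`COc1cc2ncnc(Nc3ccc(F)c(Cl)c3)c2cc1NC(=O)N/N=C/c1cc(Br)c(O)c(Br)c1`) gives 36800 nM. Compound 3 therefore sits within the scatter of compound 2, while compound 1 has a lower number than compound 3, by a gap beyond the scatter.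

Compound 4 (`CCN(CC)c1ccc(/C=N/NC(=O)Nc2cc3c(Nc4ccc(F)c(Cl)c4)ncnc3cc2OC)c(O)c1`) keeps the core of compound 3 and changes one group: 4-(diethylamino)-2-hydroxyphenyl in place of 3,5-dibromo-4-hydroxyphenyl on a carbon with a double bond to nitrogen. In words, 4-(diethylamino)-2-hydroxyphenyl comes in place of 3,5-dibromo-4-hydroxyphenyl on a carbon with a double bond to nitrogen.

Among the compounds with values here, only one measured step bears on this swap, and only in part. Adding a bromo group gave a 1.5-fold higher number from compound 2 to compound 3 (0.19 log units; within the scatter), so that step offers little sign that the bromines matter much here. The better guide is compound 1, which already carries the incoming 4-(diethylamino)-2-hydroxyphenyl group on a different core and gives 15700 nM. Within the data shown here, no measured pair isolates the swap itself, so the expectation remains loose.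

A modest move toward a lower number is expected in this assay, an estimated 1.9-fold lower number from compound 3 to compound 4 (0.29 log units; within the scatter). For compound 4 the estimated value is 19000 nM, with an expected range from 8500 nM to 40000 nM.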

Compound 4, half-maximal inhibitory concentration: 29300 nM
Compound 4: the middle estimate sits 1.5-fold (0.19 log units) below what was measured; the range from low to high includes it.
By their numbers in this assay, from the lowest: compounds 1, 2, 4 and 3 (each within the scatter of the next, the first and the last beyond it).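

Replacing 3,5-dibromo-4-hydroxyphenyl with 4-(diethylamino)-2-hydroxyphenyl on the carbon with a double bond to nitrogen gives in this assay a 1.3-fold lower number from compound 3 to compound 4 (0.10 log units; within the scatter) and replacing 3-bromo-4-hydroxyphenyl with the same group gives a 1.2-fold higher number from compound 2 to compound 4 (0.09 log units; within the scatter) so neither swap moves the number beyond the scatter. The earlier compounds shown here showed only the effect of adding one bromo group at this position, whereas these steps show that the whole aromatic group can be exchanged for one without bromine and carrying a diethylamino group, with no clear change in this cytotoxicity read-out. Within the data shown here, the result also gives a first reading at a second place: methyl in place of oxolan-3-yl on an oxygen on an aromatic ring gives a 1.9-fold higher number from compound 1 to compound 4 (0.27 log units; within the scatter) and this too stays within the scatter.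

Nothing available explains why these changes leave the number so little altered. Going by these compounds, it also remains open whether a carboxylic acid on the aromatic group at this position, or a longer alkyl chain on the oxygen, would shift the number beyond the scatter.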